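Moving the bromine on the phenyl ring of compound 2

The compounds below may be only part of what the source reports. "The series", "measured", "known", "first", "only" and "open" are said of these compounds alone.

Values measured in a functional assay on B16-F10 cells (Mus musculus) for cytotoxicity (on this read-out higher numbers stand for weaker inhibition and lower numbers for stronger inhibition), so far:
Compound 1 `O=c1oc2ccccc2c2nc3c(ccc4cc[nH]c43)c(-c3cccnc3Cl)c12` gives 70700 nM
Compound 2 `O=c1oc2ccccc2c2nc3c(ccc4cc[nH]c43)c(-c3cccc(Br)c3)c12` gives 70700 nM

Among the measured compounds shown here, on these numbers compound 2 stands level with compound 1, its nearest neighbour and the only other compound measured. Compound 3 `O=c1oc2ccccc2c2nc3c(ccc4cc[nH]c43)c(-c3ccc(Br)cc3)c12` has not yet been measured. It carries 4-bromophenyl in place of 3-bromophenyl on an aromatic carbon, opposite the ring nitrogen: 4-bromophenyl in place of 3-bromophenyl on an aromatic carbon.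

For the measured compounds named here, one measured step bears on this change: no change at the digits printed from compound 1 to compound 2 (within the scatter). That step put 3-bromophenyl in place of 2-chloropyridin-3-yl at the same carbon and left the read-out unmoved. Going by the values given here, it is only indirect evidence, since no measured pair shows what happens when the bromine alone changes position on the phenyl ring. With a larger exchange at this carbon showing no change, a step beyond the scatter is not expected here, in either direction. The expected step is a 1.0-fold lower number from compound 2 to compound 3 (0.00 log units; within the scatter) in this assay, and this remains an estimate resting on a single pair. Compound 3 is estimated at 70000 nM, with an expected range from 35000 nM to 100000 nM for the measurement.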

Compound 3, half-maximal inhibitory concentration: 70700 nM
The estimate for compound 3 lay 1.0-fold (0.00 log units) below the measured number, within the range that was stated.
By their numbers in this assay, from the lowest: compounds 1, 2 and 3 (each within the scatter of the next).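

Among the compounds shown here, the new pair is the first in which only the place of the bromine changes on the phenyl ring: in this assay, 4-bromophenyl in place of 3-bromophenyl gives no change at the digits printed from compound 2 to compound 3 (within the scatter), and the number does not respond to this shift. The direct exchange of 2-chloropyridin-3-yl for 4-bromophenyl at the same carbon, opposite the ring nitrogen, gives no change at the digits printed from compound 1 to compound 3 (within the scatter), so three different aryl groups at this position now share one printed value in this assay, where earlier only two could be compared. Nothing available on these compounds accounts for the matching values, so the result stands as an observation alone.

On these data alone, all three compounds carry a halogen on a six-membered aromatic ring at this carbon, so it remains open whether an amine, a carboxylic acid or a longer chain here would move the number away from this shared level. What changes to the shared core itself would do is also left open, since all three compounds keep it intact and differ only in this one group.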